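Metabolic stability in the ester series: working notes

The source may report more compounds than this note shows. Statements on the series, on what has been measured and on what is new or still open speak of the compounds shown alone.

Measured so far:
compound 1 `C[C@@H](O)[C@H]1C(=O)N2C(C(=O)OCOC(=O)C(C)(C)C)=C(S[C@@H]3CN[C@H](C(=O)Nc4cccc(C(=O)O)c4)C3)[C@H](C)[C@H]12`: > 95%
compound 2 `CC(C)OC(=O)C1=C(S[C@@H]2CN[C@H](C(=O)Nc3cccc(C(=O)OC(C)C)c3)C2)[C@H](C)[C@@H]2[C@@H]([C@@H](C)O)C(=O)N12`: > 95%

In an ADME assay for metabolic stability, read by LC-MS, with a stated time of 3 h, at pH 6.5, tested at 50 uM (a lower number here means that less of the compound is left, a higher number that more of the compound is left), compound 1 gives > 95%; this is a limit of the assay, not a number. Compound 2 gives > 95% in this assay, likewise a limit and not a number. Among the compounds with values here, both results sit at the same ceiling, (the limit of > 95% in this assay, at which 2 of the 2 values shown sit), so compound 2 stands at the upper limit and no measured step between the two compounds can be stated beyond that.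

Compound 3 `CC(C)OC(=O)C1=C(S[C@@H]2CN[C@H](C(=O)Nc3cccc(C(=O)O)c3)C2)[C@H](C)[C@@H]2[C@@H]([C@@H](C)O)C(=O)N12` differs from compound 2 by hydrogen in place of isopropyl on an oxygen next to a carbonyl group. Compound 1 carries the same 3-carboxyphenyl group as compound 3 and sits at the limit in this assay. Within the data shown here, no step has been measured for this change, so the expectation rests on that alone: no step beyond the scatter is expected in this assay, in either direction. The step from compound 2 to compound 3 is expected to be a number no higher from compound 2 to compound 3 (the limit leaves the size open). Compound 3 is therefore estimated at 95%, with a range from 85% to 100%, most likely reported again only as a limit.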

Compound 3, percent of the compound remaining: > 95%
Compound 3: no number, only a limit (the forecaster's own chance of this, stated with the estimate: 80%); the middle value lies on the limit itself.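

In this assay compound 3 gives > 95%, a limit and not a number. No step from compound 1 or compound 2 to compound 3 can be read: the limit of > 95% in this assay, at which 3 of the 3 values shown sit.

The compounds shown leave open whether the change from 3-(isopropoxycarbonyl)phenyl to 3-carboxyphenyl alters the percent of compound remaining at all, and by how much.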